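The source may report more compounds than this note shows. Statements on the series, on what has been measured and on what is new or still open speak of the compounds shown alone.

Measured so far:
- compound 1 `CC(=O)OC[C@H]1O[C@@H](CC(=O)/C=C/c2ccc3ccccc3c2)[C@H](OC(C)=O)[C@@H](OC(C)=O)[C@@H]1OC(C)=O` — "not determined" (no result reported)
- compound 2 `CC(=O)OC[C@H]1O[C@@H](CC(=O)/C=C/c2ccc(C(F)(F)F)cc2)[C@H](OC(C)=O)[C@@H](OC(C)=O)[C@@H]1OC(C)=O` — 103 nM
- compound 3 `COc1ccc(/C=C/C(=O)C[C@@H]2O[C@H](COC(C)=O)[C@@H](OC(C)=O)[C@H](OC(C)=O)[C@H]2OC(C)=O)cc1` — "not determined" (no result reported)

Notes on the series. Three acetylated sugar enones with an aryl-substituted double-bonded chain share one core and differ only in the aryl group. In an ADME assay on cells (Epithelial cell, Homo sapiens) for cytotoxicity, read by MTT assay, with a stated time of 24 h (a higher number here means that more compound is tolerated, a lower number that less compound is tolerated), compound 1 has no single number: its entry is "not determined" (no result reported). Compound 3 stands the same way, with "not determined" (no result reported) in this assay. Among the compounds with values here, the only number in hand belongs to compound 2, which gives 103 nM in this assay. So compound 1 cannot be placed on the numbers shown; the series has one reference point and no step between measured compounds.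

The unmeasured member is compound 4 `CC(=O)OC[C@H]1O[C@@H](CC(=O)/C=C/c2cc(Cl)cc(Cl)c2)[C@H](OC(C)=O)[C@@H](OC(C)=O)[C@@H]1OC(C)=O`. Against compound 1 the change is 3,5-dichlorophenyl in place of naphthalen-2-yl on a double-bonded chain carbon bound to a double-bonded chain carbon.

Within the data shown here, since no step is available, the size and direction of the change cannot be read from the data. The expectation rests on compound 2 alone, which gives 103 nM in this assay, and the step from compound 1 to compound 4 is expected to stay within the scatter or be modest in either direction. Compound 4 is therefore estimated at 150 nM in this assay, within 40 nM to 600 nM.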

Compound 4, half-maximal cytotoxic concentration: 32.9 nM
Beside the measured number, compound 4's estimate is 4.6-fold (0.66 log units) above it; measured number below the stated range.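

In this assay, the place on a double-bonded chain carbon bound to a double-bonded chain carbon now has its first readable step: 3,5-dichlorophenyl in place of 4-(trifluoromethyl)phenyl gives a 3.1-fold lower number from compound 2 to compound 4 (0.50 log units; beyond the scatter) on the shared core. The read-out therefore responds to a change of aryl group at this place, which a single number could not show, and the direction here is towards less compound being tolerated. The steps from compound 1 and compound 3 to compound 4 cannot be read, so the exchange of naphthalen-2-yl for 3,5-dichlorophenyl still has no size, and nothing in hand accounts for the step from the trifluoromethyl-bearing aryl group to the dichlorinated one.

Within the data shown here, with only two numbers, no trend across aryl groups can be drawn, and the place of compound 1 and compound 3 relative to these two remains unknown. Also open, going by these compounds, is how a phenyl group carrying an amine or a carboxylic acid would read at this place, and whether free hydroxyl groups in place of the acetates would shift the values of the series.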